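The compounds below may be only part of what the source reports. "The series", "measured", "known", "first", "only" and "open" are said of these compounds alone.

Compound 1 `CCOC(=O)[C@]1(C(=O)Nc2ccccc2)C[C@H]1c1cc(OC)c(OC)c(OC)c1`: > 100000 nM (a limit)
Compound 2 `CCOC(=O)[C@@]1(C(=O)NCc2ccc(C)cc2)C[C@H]1c1cc(OC)c(OC)c(OC)c1`: 19700 nM

Among the measured compounds shown here, in a functional assay on HeLa cells (Homo sapiens) for cytotoxicity, read by MTT assay, with a stated time of 48 h (a higher number here means a weaker inhibitor, a lower number a stronger inhibitor), compound 2 gives 19700 nM, the only actual number so far. For compound 1, > 100000 nM is a limit of the assay, not a number. Compound 3 `CCOC(=O)[C@]1(C(=O)NCc2ccc(C)cc2)C[C@H]1c1cc(OC)c(OC)c(OC)c1` is a close relative of compound 2: the two compounds have the same atoms and bonds and differ only in configuration as drawn: 1 of 2 stereo elements differ; a stereocentre at a saturated ring carbon is drawn S in compound 2 and R in compound 3. For the measured compounds named here, no measured pair shows what such a change does, so this expectation is tentative: a modest weakening in this assay, though a result within the scatter would be unsurprising. The expected change is a 1.8-fold higher number from compound 2 to compound 3 (0.25 log units; within the scatter). The estimate for compound 3 is 35000 nM, with an expected range of 10000 nM to 100000 nM.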

Compound 3, half-maximal inhibitory concentration: 28500 nM
Estimate against measurement, compound 3: 1.2-fold (0.09 log units) above, within the range that was stated.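

In this assay the change of one stereocentre at a saturated ring carbon gives a 1.4-fold higher number from compound 2 to compound 3 (0.16 log units; within the scatter) and so makes no clear difference at this position. Among the compounds shown here, putting 4-methylbenzyl in place of phenyl on the amide-type nitrogen gives an at least 3.5-fold lower number from compound 1 to compound 3 (0.54 log units; beyond the scatter) and this is the only step here beyond the scatter. Compound 1 stands at a limit, not a number, so that step gives only a minimum: the limit of > 100000 nM in this assay, at which 1 of the 3 values shown sits.

The compounds shown leave open what a plain benzyl or a longer chain such as phenethyl would do on that nitrogen. They also leave open what a carboxylic acid in place of the ethyl ester would do.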